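This account rests on a few compounds, and the source may have more. Where it says the series, first, only, none or still open, it means among the compounds named here.

Of the compounds shown here, three have been measured in an assay for inhibition of inositol hexakisphosphate kinase 2 (Homo sapiens), read by colorimetric assay, coupled enzyme assay and malachite green, with a stated time of 120 min, in the presence of a further agent that is not named here; on this read-out higher numbers stand for weaker inhibition and lower numbers for stronger inhibition. Compound 1, `Cc1cccc(-c2onc3ccc(/C=C/C(=O)O)cc23)c1`, gives 290 nM. Compound 2, `CNC(=O)c1ccc2noc(-c3ccccc3)c2c1`, gives 2120 nM. Compound 3, `O=C(O)c1ccc2noc(-c3ccc(-c4ccncc4)cc3)c2c1`, gives 150 nM. Compound 3 thus stands at the lowest of the three numbers, but its gap to compound 1 is within the scatter of repeated measurements, so the two cannot be told apart on these data; only compound 2 lies clearly beyond the scatter, at the weak end.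

Compound 4, `O=C(O)c1ccc2noc(-c3ccc(NC(=O)C4CCCC4)cc3)c2c1`, has not yet been measured. It is built from compound 3 by one change: (cyclopentylcarbonyl)amino in place of pyridin-4-yl on an aromatic carbon. The carboxylic acid on the shared core is kept, and the change sits on the second aromatic ring, where the pyridin-4-yl of compound 3 is swapped for (cyclopentylcarbonyl)amino, bringing one hydrogen-bond donor into the molecule.

Among the compounds with values here, no measured pair in this set shows what such a swap does, so the expectation rests only on compound 3. The step from compound 3 to compound 4 is expected to be small, a 1.9-fold higher number from compound 3 to compound 4 (0.27 log units; within the scatter), leaning slightly toward weaker inhibition but not beyond the scatter. Compound 4 is therefore estimated to give about 280 nM, with a plausible range from 70 nM to 1100 nM.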

Compound 4, half-maximal inhibitory concentration: 190 nM
The estimate for compound 4 lay 1.5-fold (0.17 log units) above the measured number; measured number inside the range.
By their numbers in this assay, from the lowest: compounds 3, 4 and 1 (each within the scatter of the next); then compound 2.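

Placing (cyclopentylcarbonyl)amino instead of pyridin-4-yl on this aromatic carbon, para to a large group, gives a 1.3-fold higher number from compound 3 to compound 4 (0.10 log units; within the scatter) in this assay, so the two compounds cannot be told apart on this read-out. Within the data shown here, this is the first sign that this position can hold quite different groups: the six-membered aromatic ring with its hetero atom leaves, while a five-membered non-aromatic ring of carbon only, a carbonyl and the amide hydrogen enter, and the number stays within the scatter, though this rests on a single pair of compounds. No measurement shown here accounts for the two groups reading alike.

As far as these compounds go, it remains open whether the amide hydrogen matters, which a methyl group on the amide nitrogen would test, and whether the cyclopentyl ring can be exchanged for a cyclohexyl ring or a plain methyl group without moving the number beyond the scatter. From the compounds shown here alone, the carboxylic acid also remains untested, and a tetrazole in its place on compound 4 would show whether that group can be exchanged too.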